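Working notes on the shared core: methoxy to trifluoromethyl

This account rests on a few compounds, and the source may have more. Where it says the series, first, only, none or still open, it means among the compounds named here.

Values in an assay on isolated protein for inhibition of DNA topoisomerase 1 (Homo sapiens), with a stated time of 30 min, tested at 100 uM; a lower number here means a weaker effect, a higher number a stronger effect of the compound at the concentration tested:
compound 1, `COc1cccc(-c2nc3ccc(N4CCCCC4)cc3c(=O)[nH]2)c1OC`, gives 80.9%
compound 2, `Cc1ccc2nc(-c3cccc(OC(F)(F)F)c3)[nH]c(=O)c2c1`, gives 98.6%
compound 3, `COc1cccc(-c2nc3cc(C)ccc3c(=O)[nH]2)c1`, gives 100%

Compound 3 stands highest of the three numbers in this assay. The nearest is compound 2, whose number lies within the scatter of that of compound 3, so no order between the two can be read. Compound 1 lies beyond the scatter below compound 3 and is the only one of the three that reads clearly lower.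

Compound 4, `Cc1ccc2c(=O)[nH]c(-c3cccc(C(F)(F)F)c3)nc2c1`, is not yet measured. It differs from compound 3 in one place: trifluoromethyl in place of methoxy on an aromatic carbon. Among the measured compounds shown here, no step between measured compounds is available for this change. The expected step from compound 3 to compound 4 in this assay is a number 3 percentage points lower from compound 3 to compound 4 (within the scatter), that is, none beyond the scatter, and since compound 3 already reads at the top of the scale, no rise is possible. This expectation rests on compound 2, which carries a different fluorinated group on the same kind of ring and gives 98.6%. Compound 4 is expected to give 97%, within 85% to 100%.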

Compound 4, a percentage reported as inhibition, at one concentration (the size of the read-out at that concentration, not a potency): 100%
The estimate for compound 4 lay 3 percentage points below the measured number; measured number inside the range.
By their numbers in this assay, from the lowest: compound 1; then compounds 2, 3 and 4 (each within the scatter of the next).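

In this assay, trifluoromethyl in place of methoxy on an aromatic carbon gives no change at the digits printed from compound 3 to compound 4 (within the scatter), so this position of the six-membered aromatic ring of carbon only accepts either group without a visible shift in the read-out. The change removes the hydrogen-bond acceptor counted for methoxy and adds heavy atoms, yet both compounds read at the top of the scale at a single concentration, so any difference in potency between them stays hidden. Nothing measured here accounts for this outcome.

From the compounds shown here alone, whether the read-out holds with an amine, a carboxylic acid or a longer chain such as butoxy on this carbon remains open. A measurement that brings compound 3 and compound 4 off the top of the scale is also still needed to separate the two groups.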